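Halogen swap on the aryl ring across two cores

A few compounds are considered here, and "the series" means these few. Any claim that something is new, unique, unknown or untested is made for them only; others in the source may bear on it.

Compound 1 `O=C1CSC(N2N=C(c3ccc(Br)cc3)CC2c2ccc3ccccc3c2)=N1` and compound 2 `O=C1CSC(N2N=C(c3ccc(Cl)cc3)CC2c2ccc3ccccc3c2)=N1` share one core; compound 3 `Clc1ccc(C2=NN(C3=NC(c4ccccc4)CS3)C(c3cccc4ccccc34)C2)cc1` and compound 4 `Brc1ccc(C2=NN(C3=NC(c4ccccc4)CS3)C(c3cccc4ccccc34)C2)cc1` share another. In a functional assay on HeLa cells (Homo sapiens) for inhibition, read by CCK-8 assay, with a stated time of 48 h (on this read-out lower numbers stand for stronger inhibition and higher numbers for weaker inhibition), compound 1 gives 4220 nM, compound 2 gives 6320 nM, and compound 3 gives 9940 nM. Compound 3 has the highest number of the three measured, a gap to compound 1 beyond the scatter, while compound 3 and compound 2 lie within the scatter of each other. The difference between the core of compound 2 and the core of compound 3 is not broken down here.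

The change bromo in place of chloro on an aromatic carbon gave a 1.5-fold lower number from compound 2 to compound 1 (0.18 log units; within the scatter). The same change, (bromo in place of chloro on an aromatic carbon), now carries compound 3 to compound 4; the two place descriptions agree word for word, so it is the same change on a different core. Among the measured compounds shown here, only this one earlier instance exists, so the expectation rests on it alone and on compound 3 at 9940 nM. Compound 4 is expected to show a 1.5-fold lower number from compound 3 to compound 4 (0.18 log units; within the scatter), a small step at most. Compound 4 is therefore estimated at 6600 nM, between 3000 nM and 14000 nM in this assay.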

Compound 4, half-maximal inhibitory concentration: 6650 nM
Estimate against measurement, compound 4: 1.0-fold (0.00 log units) below; measured number inside the range.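

Working notes on the halogen swap: in this assay the change from 4-chlorophenyl to 4-bromophenyl gives a 1.5-fold lower number from compound 3 to compound 4 (0.17 log units; within the scatter) on the second core. Within this series, the change carries from one core to the other with no visible difference in the size of the step: the same change on two cores in this assay, a 1.5-fold lower number (0.18 log units; within the scatter) from compound 2 to compound 1 and a 1.5-fold lower number (0.17 log units; within the scatter) from compound 3 to compound 4, 1.0-fold (0.00 log units) apart, within the scatter of two such steps

Among the compounds shown here, this agreement rests on only two pairs, and since each step lies within the scatter, it does not show that bromo gives stronger inhibition than chloro on either core, only that the swap leaves the number little moved in both.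

Still open, from the compounds shown here alone, is whether a different group on the same aromatic carbon, such as fluoro, methoxy, nitrile or an amine, would give a step beyond the scatter on either core, and whether such a step would carry from one core to the other. Also open is how much the two cores themselves contribute, as no pair shown differs in the core alone.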